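A few compounds are considered here, and "the series" means these few. Any claim that something is new, unique, unknown or untested is made for them only; others in the source may bear on it.

The numbers here come from an ADME assay on Vero cells (Chlorocebus sabaeus) for cytotoxicity, read by MTT assay, with a stated time of 72 h; a lower number here means that less compound is tolerated, a higher number that more compound is tolerated. For compound 1 (`C[C@]1(CN2CCc3nc(C4CCOCC4)ccc3C2)Cn2cc([N+](=O)[O-])nc2O1`) the entry reads "not determined" (no result reported). Compound 2 (`C[C@]1(CN2CCc3nc(-c4ccccc4F)ccc3C2)Cn2cc([N+](=O)[O-])nc2O1`) gives > 32 ug/mL, which is a limit of the assay and not a number. Compound 3 (`C[C@]1(CN2CCc3nc(-c4ccc(F)c(Cl)c4)ccc3C2)Cn2cc([N+](=O)[O-])nc2O1`) gives > 32 ug/mL, again a limit and not a number. That places compound 3 at the limit of > 32 ug/mL in this assay, at which 2 of the 3 values shown sit, so its standing is known only as a limit.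

Compound 4 (`C[C@]1(CN2CCc3nc(-c4ccc(Cl)cc4F)ccc3C2)Cn2cc([N+](=O)[O-])nc2O1`) has not yet been measured in this assay. It carries 4-chloro-2-fluorophenyl in place of the 3-chloro-4-fluorophenyl of compound 3, on an aromatic carbon next to the ring nitrogen: 4-chloro-2-fluorophenyl in place of 3-chloro-4-fluorophenyl on an aromatic carbon.

For the measured compounds named here, the one measured step that bears on this swap is a step that the two limits leave unreadable from compound 2 to compound 3. It is also a change of phenyl group, but it gives no size to carry over. No change beyond the usual scatter is therefore expected, in either direction, and another limit is the likeliest report. The expected step is a step that the limit leaves unreadable from compound 3 to compound 4. For compound 4 the estimate is 45 ug/mL, with an expected range from 24 ug/mL to 90 ug/mL.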

Compound 4, half-maximal cytotoxic concentration: > 32 ug/mL
Compound 4 ended at the assay's limit (the forecaster's own chance of this, stated with the estimate: 85%); the middle value is on the limit's open side.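

Compound 4, like compound 2 and compound 3, gives a limit and not a number, so none of the steps among these three compounds in this assay can be read: the limit of > 32 ug/mL in this assay, at which 3 of the 4 values shown sit.

The compounds shown leave open whether these three differ from one another at all in this assay.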